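Fluoro to methyl on the phenoxyacetic acid of compound 3

The compounds below may be only part of what the source reports. "The series", "measured", "known", "first", "only" and "open" are said of these compounds alone.

The measured compounds:
compound 1, `Cc1cccc(-c2nc(C)c(COc3ccc(OCC(=O)O)c(F)c3)s2)c1`, 247 nM in an assay on CHO cells for agonist activity at Free fatty acid receptor 1 (Homo sapiens), read by FLIPR; a higher number here means that more compound is needed for the effect, a lower number that less compound is needed;
compound 2, `Cc1sc(-c2ccccc2)nc1COc1ccc(OCC(=O)O)c(F)c1`, > 10000 nM;
compound 3, `O=C(O)COc1ccc(OCc2csc(-c3ccccc3)n2)cc1F`, > 10000 nM.

Compound 3 does not stand on a number: its value in this assay is a limit of the assay. The same holds for compound 2, whose value is also a limit. For the measured compounds named here, compound 1 is the only compound of the three with a measured number. Going by the values given here, the one step among measured compounds, a step that the two limits leave unreadable from compound 2 to compound 3, starts and ends at the limit and therefore gives no readable size; it also concerns a different place than the change now at hand.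

Compound 4, `Cc1cc(OCc2csc(-c3ccccc3)n2)ccc1OCC(=O)O`, differs from compound 3 by methyl in place of fluoro on an aromatic carbon. Among the compounds with values here, no measured step bears on this change, and compound 3 itself gives only a limit. With two of the three shown values sitting at the limit (the limit of > 10000 nM in this assay, at which 2 of the 3 values shown sit), the expectation for compound 4 is that the step of a number no higher from compound 3 to compound 4 (the limit leaves the size open) stays unreadable and that compound 4 again reports a limit. The estimate for compound 4 is 10000 nM, in the range 2000 nM to 30000 nM.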

Compound 4, half-maximal effective concentration: > 10000 nM
Compound 4 gave a limit, no number; the forecaster's own chance of this, stated with the estimate: 70%; the middle value sits exactly at the limit.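

No step can be read from compound 3 to compound 4 in this assay: each of the two reports only a limit of the assay, not a number. The compounds shown leave open how methyl and fluoro on this aromatic carbon compare in a compound that gives a measured number.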